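From a Short Ester Chain to a Cyclopentyl Ketone

The source may hold more compounds than are shown below. What is called first, only, known or untested is meant among the compounds shown, and "the series" means these compounds.

Compound 1 `COC(=O)CCC(=O)c1ncc(-c2ccccn2)o1` was tested in an assay for inhibition of Fatty-acid amide hydrolase 1 (Rattus norvegicus); a higher number here means a weaker inhibitor, a lower number a stronger inhibitor. In this assay compound 1 gives > 100000 nM, which is a limit of the assay rather than a number, and so compound 1 stands at the limit of > 100000 nM in this assay, at which 1 of the 3 values shown sits. Compound 2 `COC(=O)CCCC(=O)c1ncc(-c2ccccn2)o1` gives 7000 nM in this assay, and compound 3 `COC(=O)CCCCC(=O)c1ncc(-c2ccccn2)o1` gives 1800 nM. Among these three, an at least 14-fold lower number from compound 1 to compound 2 (1.15 log units; beyond the scatter), an at least 55-fold lower number from compound 1 to compound 3 (1.74 log units; beyond the scatter) and a 3.9-fold lower number from compound 2 to compound 3 (0.59 log units; beyond the scatter); every extension of the ester chain lowers the number. Compound 4 `O=C(c1ncc(-c2ccccn2)o1)C1CCCC1` differs from compound 1 in that (cyclopentyl in place of 2-(methoxycarbonyl)ethyl on a carbonyl carbon). The measured steps all keep an ester and only alter its length; none replaces it with a ring, so they bear on this change only by showing that the group on this carbonyl carbon moves the number strongly. For compound 4 the estimated step is therefore an at least 50-fold lower number from compound 1 to compound 4 (1.69 log units; beyond the scatter), towards a lower number. Compound 4 is expected to give about 2000 nM in this assay, with a range from 200 nM to 20000 nM.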

Compound 4, inhibition constant: 2500 nM
Beside the measured number, compound 4's estimate is 1.3-fold (0.10 log units) below it; the range from low to high includes it.
By their numbers in this assay, from the lowest: compounds 3 and 4 (each within the scatter of the next); then compound 2. At a limit, above all of these: compound 1.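

Putting cyclopentyl on this carbonyl carbon gives an at least 40-fold lower number from compound 1 to compound 4 (1.60 log units; beyond the scatter), so an ester is not needed here for a measurable number in this assay: the entering group has no oxygen and no hydrogen-bond acceptors. Compound 4 at 2500 nM and compound 3 at 1800 nM lie within the scatter of each other, so a ring of carbon only matches the longest ester chain shown. The true size of the step remains open, since compound 1 has only a limit of the assay rather than a number: the limit of > 100000 nM in this assay, at which 1 of the 4 values shown sits.

It also remains unclear whether the ring itself matters, or whether any group of similar size would do as well. A cyclohexyl ring, an unbranched pentyl chain or a carboxylic acid at the end of a longer chain could help separate these possibilities.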